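A few compounds are considered here, and "the series" means these few. Any claim that something is new, unique, unknown or untested is made for them only; others in the source may bear on it.

Working notes on the series, read in a functional assay on THP-1 cells (Homo sapiens) for inhibition, read by sulforhodamine B assay, with a stated time of 48 h; a higher number here means a weaker inhibitor, a lower number a stronger inhibitor. Compound 1 `COc1ccc(C(c2ccc(OCCO)cc2)c2cccc3ccccc23)c(OC)c1OC` gives 16600 nM, and compound 2 `COc1ccc(C(c2ccc(O)cc2)c2cccc3ccccc23)c(OC)c1OC` gives 9450 nM, with a 1.8-fold lower number from compound 1 to compound 2 (0.24 log units; within the scatter). Compound 3 `C=CCOC(c1ccc(OC)c(OC)c1OC)c1cccc2ccccc12` reads > 20000 nM, which is a limit of the assay and not a number. Compound 4 `COc1ccc(C(OCc2ccc(C)cc2)c2cccc3ccccc23)c(OC)c1OC` differs from it by 4-methylphenyl in place of vinyl on a saturated chain carbon bound to an oxygen on a saturated carbon, with 4-methylphenyl in place of vinyl. The closest measured changes are those that put allyloxy in place of a substituted phenyl: an at least 2.1-fold higher number from compound 2 to compound 3 (0.32 log units; beyond the scatter) and an at least 1.2-fold higher number from compound 1 to compound 3 (0.08 log units; that floor lies within the scatter). Going by the values given here, both are floors, so they suggest only that restoring an aromatic ring may give a modest lowering in this assay. The expected step is an at least 1.4-fold lower number from compound 3 to compound 4 (0.15 log units; that floor lies within the scatter). For compound 4 the estimate is 14000 nM, with an expected range of 7000 nM to 25000 nM.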

Compound 4, half-maximal inhibitory concentration: > 20000 nM
Compound 4 was reported as a limit (the forecaster's own chance of this, stated with the estimate: 40%); middle value at least 1.4-fold (0.15 log units) from the limit.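

In this assay compound 4 gives only a limit of the assay and not a number, so the step between the two limits cannot be read: the limit of > 20000 nM in this assay, at which 2 of the 4 values shown sit.

The (4-methylbenzyl)oxy group gives an at least 2.1-fold higher number from compound 2 to compound 4 (0.32 log units; beyond the scatter), and an at least 1.2-fold higher number from compound 1 to compound 4 (0.08 log units; that floor lies within the scatter). An aromatic ring carried on the allyloxy-type chain therefore gives no readable value here, unlike the 4-hydroxyphenyl group of compound 2.

On these data alone, whether a chain ending in an amine or a carboxylic acid at this carbon gives a readable value remains open. As far as these compounds go, the true distance between compound 3 and compound 4 also remains open.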